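From pyridin-3-yl to pyridin-4-yl: what to expect

The source may report more compounds than this note shows. Statements on the series, on what has been measured and on what is new or still open speak of the compounds shown alone.

In an ADME assay on RAW264.7 cells (Mus musculus) for cytotoxicity, read by MTT assay, with a stated time of 48 h (on this read-out higher numbers stand for weaker inhibition and lower numbers for stronger inhibition), compound 1 `Fc1ccc(-c2ccc(CNCCCNc3ccnc4cc(Cl)ccc34)s2)cc1` gives 6890 nM, while compound 2 `Clc1ccc2c(NCCCNCc3ccc(-c4cccnc4)s3)ccnc2c1` gives 21600 nM. Within the data shown here, compound 2 therefore holds the higher of the two numbers so far, which means the weaker inhibition. Compound 3 `Clc1ccc2c(NCCCNCc3ccc(-c4ccncc4)s3)ccnc2c1` has pyridin-4-yl in place of pyridin-3-yl on an aromatic carbon. Among the measured compounds shown here, only one measured step bears on this change, and it is an imperfect guide. Replacing 4-fluorophenyl with pyridin-3-yl gave a 3.1-fold higher number from compound 1 to compound 2 (0.50 log units; beyond the scatter), a modest step from a different swap of groups. For the measured compounds named here, no measured pair compares the two pyridine forms directly, so a smaller step is expected here, one within the scatter in this assay and with no favoured direction. The expected change is a 1.1-fold lower number from compound 2 to compound 3 (0.03 log units; within the scatter). For compound 3, the estimated value is 20000 nM, with an expected range of 9000 nM to 45000 nM.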

Compound 3, half-maximal inhibitory concentration: 3320 nM
The estimate for compound 3 lay 6.0-fold (0.78 log units) above the measured number; measured number below the stated range.
By their numbers in this assay, from the lowest: compound 3; then compound 1; then compound 2.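

In this assay pyridin-4-yl in place of pyridin-3-yl gives a 6.5-fold lower number from compound 2 to compound 3 (0.81 log units; beyond the scatter) on an aromatic carbon of a five-membered aromatic ring with 1 sulfur, so two groups with the same atoms and the same donor and acceptor counts can read very differently at this place. Pyridin-4-yl in place of 4-fluorophenyl then gives a 2.1-fold lower number from compound 1 to compound 3 (0.32 log units; beyond the scatter) and this runs opposite to the earlier step to pyridin-3-yl, so swapping 4-fluorophenyl for a pyridine ring has no single direction here: compound 3 lies below compound 1, and compound 2 lies above it. Nothing measured here accounts for the gap between the two pyridine forms. On these data alone, it remains open how pyridin-2-yl or a plain phenyl group would read at this place. The compounds shown also leave open whether the same order would hold in any other assay.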